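The source may hold more compounds than are shown below. What is called first, only, known or untested is meant among the compounds shown, and "the series" means these compounds.

Three members of one series have been measured in a functional assay on PC-3 cells (Homo sapiens) for antiproliferative activity, read by XTT assay; a lower number here means a stronger inhibitor, a higher number a weaker inhibitor. Compound 1, `O=c1c(Cc2coc3cccc(OCC4CCCCC4)c3c2=O)coc2cc(O)ccc12`, gives 4250 nM in this assay. Going by the values given here, compound 2, `Cc1ccc2c(=O)c(Cc3coc4cccc(OCC5CCCCC5)c4c3=O)coc2c1`, gives 2440 nM in this assay, and the single measured step, a 1.7-fold lower number from compound 1 to compound 2 (0.24 log units; within the scatter), lies within the scatter. Compound 3, `CC(C)CCOc1cccc2occ(Cc3coc4ccccc4c3=O)c(=O)c12`, is the third member. In this assay compound 3 gives only a limit, > 10000 nM, and so stands at the limit of > 10000 nM in this assay, at which 1 of the 3 values shown sits, rather than at a number.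

Compound 4, `O=c1c(Cc2coc3cccc(O)c3c2=O)coc2ccccc12`, differs from compound 3 in one place: hydrogen in place of isopentyl on an oxygen on an aromatic ring. Among the compounds with values here, none of the measured steps touches this oxygen; the one step that has been measured, a 1.7-fold lower number from compound 1 to compound 2 (0.24 log units; within the scatter), concerns a different position and was within the scatter, so it does not bear on this change. Because compound 3 is known only through > 10000 nM, the step of an at least 1.2-fold lower number from compound 3 to compound 4 (0.09 log units; that floor lies within the scatter) is expected only loosely, with no firm direction. Compound 4 is estimated at 8000 nM in this assay, within a range from 2000 nM to 30000 nM.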

Compound 4, half-maximal inhibitory concentration: 5950 nM
Estimate against measurement, compound 4: 1.3-fold (0.13 log units) above; the measured number falls inside the stated range.
By their numbers in this assay, from the lowest: compounds 2, 1 and 4 (each within the scatter of the next, the first and the last beyond it). At a limit, above all of these: compound 3.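

The change from isopentyloxy to hydroxy on this oxygen on an aromatic ring reads an at least 1.6-fold lower number from compound 3 to compound 4 (0.22 log units; that floor lies within the scatter). With hydrogen in place of isopentyl, compound 4 gives a number in this assay, so the isopentyl group is not needed for a numerical reading on this core. The true size of the step remains unknown, and its floor lies within the scatter, because the comparison rests on a limit: the limit of > 10000 nM in this assay, at which 1 of the 4 values shown sits.

The compounds shown leave open how a methyl group, a longer chain or a chain ending in an amine on this oxygen would compare with the hydroxy of compound 4. They also leave open how a cyclohexylmethyl group on this oxygen would compare on the core of compound 4.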